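Swapping one chloro for fluoro at high solubility

A few compounds are considered here, and "the series" means these few. Any claim that something is new, unique, unknown or untested is made for them only; others in the source may bear on it.

Compound 1 `Cc1cc(CN(CC2CCCC2)C(CC(=O)O)c2ccc(Cl)cc2)ccc1OCCN1C(=O)CCC1=O` gives 3000000 nM in this series
Compound 2 `COc1cc(CN(CC(C)C)C(CC(=O)O)c2ccc3c(c2)CCO3)ccc1OCCN1C(=O)CCC1=O` gives 3000000 nM in this series
Compound 3 `COc1cc(CN(CC(C)C)C(CC(=O)O)c2ccc(Cl)c(Cl)c2)ccc1OCCN1C(=O)CCC1=O` gives 3000000 nM in this series
Compound 4 `COc1cc(CN(CC(C)C)C(CC(=O)O)c2ccc(Cl)c(F)c2)ccc1OCCN1C(=O)CCC1=O` has no value yet

All these values come from a physicochemical assay for solubility, at pH 1.1 (on this read-out higher numbers stand for higher solubility and lower numbers for lower solubility), and compound 3 stands level with compound 1 and compound 2 at the digits shown. The next structure, compound 4, differs from compound 3 in a single atom: fluoro in place of chloro on an aromatic carbon with fluoro in place of chloro on an aromatic carbon. This turns 3,4-dichlorophenyl into 4-chloro-3-fluorophenyl.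

Among the measured compounds shown here, one measured step bears on this. In no change at the digits printed from compound 2 to compound 3 (within the scatter) a whole group was replaced on a saturated chain carbon, yet the step stayed within the scatter. For the measured compounds named here, no measured pair isolates a chloro to fluoro swap, so this evidence is indirect. The present swap is far smaller, so no step beyond the scatter is expected in this assay for it.

The estimate means no change at the digits printed from compound 3 to compound 4 (within the scatter) as the expected outcome. Compound 4 is expected at 3000000 nM with an estimated range from 1500000 nM to 3500000 nM in this measurement.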

Compound 4, solubility: 3000000 nM
Compound 4: middle estimate and measured number agree at the digits printed, and the stated range covers the measured number.
By their numbers in this assay, from the lowest: compounds 1, 2, 3 and 4 (each within the scatter of the next).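

Fluoro in place of chloro on this aromatic carbon is the first single-atom change tested in this series, and in this assay it gives no change at the digits printed from compound 3 to compound 4 (within the scatter) so here the two halogens cannot be told apart. The whole-group replacement, now made with the 4-chloro-3-fluorophenyl group, likewise gives no change at the digits printed from compound 2 to compound 4 (within the scatter) and so matches what the 3,4-dichlorophenyl group showed earlier. No measurement here gives a reason for these flat results.

Still open, from the compounds shown here alone, is whether a bromo, a nitrile or an amine on this same aromatic carbon would give the same reading. Also open, going by these compounds, is what happens when the remaining chloro of the 4-chloro-3-fluorophenyl group gives way to a second fluoro.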